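The compounds below may be only part of what the source reports. "The series", "measured", "known", "first", "only" and "open" are said of these compounds alone.

Measured so far in an ADME assay for permeability, using PAMPA, at pH 4; on this read-out lower numbers stand for lower permeability and higher numbers for higher permeability:
- compound 1 `CCc1c(C)[nH]c2cc(OC)c(Cl)cc2c1=O` gives 96.4 10^-6 cm/s
- compound 2 `COc1cc2[nH]c(C)c(C3CCCCC3)c(=O)c2cc1Cl` gives 1240 10^-6 cm/s
- compound 3 `COc1cc2[nH]c(C)c(C(C)C)c(=O)c2cc1Cl` gives 281 10^-6 cm/s

Compound 3 holds the second highest of the three numbers, nearer to compound 1 than to compound 2. Compound 4 `COc1cc2[nH]c(C)c(Br)c(=O)c2cc1Cl` has bromo in place of isopropyl on an aromatic carbon. Among the measured compounds shown here, no measured compound carries bromo, so the only guide is the other changes at this place: the large step (a 13-fold higher number from compound 1 to compound 2 (1.11 log units; beyond the scatter)) and the two modest ones (a 2.9-fold higher number from compound 1 to compound 3 (0.46 log units; beyond the scatter)) and (a 4.4-fold lower number from compound 2 to compound 3 (0.64 log units; beyond the scatter)). Across these three compounds, the number climbs from ethyl through isopropyl to cyclohexyl, and none goes against this. With a single atom entering, a modest drop is expected (a 2.4-fold lower number from compound 3 to compound 4 (0.39 log units; beyond the scatter)). Compound 4 is estimated at 115 10^-6 cm/s, with an expected range from 40 10^-6 cm/s to 330 10^-6 cm/s.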

Compound 4, apparent permeability: 125 10^-6 cm/s
Compound 4: the middle estimate sits 1.1-fold (0.04 log units) below what was measured, and the stated range covers the measured number.
By their numbers in this assay, from the lowest: compounds 1 and 4 (each within the scatter of the next); then compound 3; then compound 2.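

In this assay, among the compounds shown here, bromo, the first group at this place that is not a carbon group, gives a lower number than isopropyl (a 2.2-fold lower number from compound 3 to compound 4 (0.35 log units; beyond the scatter)) and than cyclohexyl (a 9.9-fold lower number from compound 2 to compound 4 (1.00 log units; beyond the scatter)). Against ethyl it stays within the scatter (a 1.3-fold higher number from compound 1 to compound 4 (0.11 log units; within the scatter)), so the single bromine atom reads level with that two-carbon group. Nothing at hand explains this result. On these data alone, whether chloro, an amine or a carboxylic acid at this place would stay near these numbers remains open.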